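Removing the triazolyl group from compound 1

The compounds below may be only part of what the source reports. "The series", "measured", "known", "first", "only" and "open" are said of these compounds alone.

- compound 1 `O=C(O)CCSC(CCc1ccccc1-c1nc[nH]n1)c1cccc(OCc2ccc3ccc(Cl)cc3n2)c1`: 64 mL/min/kg
- compound 2 `CCC(CSC(CCc1ccccc1C(=O)O)c1cccc(OCc2ccc3ccc(Cl)cc3n2)c1)C(=O)O`: 8.8 mL/min/kg

In an in vivo ADME assay on the whole organism (plasma) for pharmacokinetics, with Rattus norvegicus as the target, at a dose of 5 mg/kg by the intravenous route (on this read-out higher numbers stand for fast clearance and lower numbers for slow clearance), compound 1 stands highest of the two measured compounds at 64 mL/min/kg, and compound 2 gives 8.8 mL/min/kg. The gap between these two values lies well beyond the scatter. Compound 3 `O=C(O)CCSC(CCc1ccccc1)c1cccc(OCc2ccc3ccc(Cl)cc3n2)c1` follows from compound 1 by one change, (hydrogen in place of 1H-1,2,4-triazol-3-yl on an aromatic carbon), with hydrogen in place of 1H-1,2,4-triazol-3-yl on an aromatic carbon. Within the data shown here, no measured pair shows this change, so the expectation is loose: a moderate fall, possibly not beyond the scatter, since compound 1 already starts high at 64 mL/min/kg. The expected change is a 1.8-fold lower number from compound 1 to compound 3 (0.26 log units; within the scatter). For compound 3 the estimated clearance is 35 mL/min/kg, with an expected range of 12 mL/min/kg to 80 mL/min/kg.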

Compound 3, clearance: 2.9 mL/min/kg
Compound 3: the middle estimate sits 12-fold (1.08 log units) above what was measured, and the stated range ends above it.
By their numbers in this assay, from the lowest: compound 3; then compound 2; then compound 1.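

In this assay, replacing the 1H-1,2,4-triazol-3-yl on the aromatic carbon with hydrogen gives a 22-fold lower number from compound 1 to compound 3 (1.34 log units; beyond the scatter), a large step beyond the scatter. At this place on the six-membered aromatic ring, the substituent therefore has a strong bearing on rat clearance, and the bare ring of compound 3 gives slow clearance. Nothing available explains the size of this step. Still open, from the compounds shown here alone, is where between these two extremes a smaller substituent such as methoxy or an amine at the same place would fall. Going by these compounds, whether the step would be as large with another thioether side chain also remains open.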